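The source may report more compounds than this note shows. Statements on the series, on what has been measured and on what is new or still open speak of the compounds shown alone.

Measured so far in an assay on HepG2 cells for agonist activity at nuclear receptor subfamily 1 group I member 3 (Homo sapiens), read by a luciferase reporter, with a stated time of 23 h; a higher number here means that more compound is needed for the effect, a lower number that less compound is needed:
- compound 1 `COc1ccc(CO/N=C/c2c(-c3ccc4ccccc4c3)nc3occn23)cc1` gives 4400 nM
- compound 2 `Clc1ccc(CO/N=C/c2c(-c3cccc4ccccc34)nc3sccn23)cc1Cl` gives 940 nM
- compound 3 `Clc1ccc(-c2nc3occn3c2/C=N/OCc2ccc(Cl)c(Cl)c2)cc1` gives 410 nM

Compound 2 holds the second highest of the three numbers in this assay. Its nearest neighbour is compound 3, whose number is lower by a gap beyond the scatter; compound 1 sits furthest away, with a higher number, again beyond the scatter. Going by the values given here, no pair among the measured compounds differs in one place only, so no single-change step is available to lean on.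

The next compound, compound 4 `FC(F)(F)c1ccc(-c2nc3sccn3c2/C=N/OCc2ccc(Cl)c(Cl)c2)cc1`, differs from compound 2 as follows: 4-(trifluoromethyl)phenyl in place of naphthalen-1-yl on an aromatic carbon. Among the compounds with values here, compound 3, the only measured compound carrying a single six-membered aromatic ring at that place, gives the lowest number of the three, though it also differs from compound 2 in the fused core. On this slim basis a modest move toward a lower number is expected for compound 4, a step of a 1.9-fold lower number from compound 2 to compound 4 (0.27 log units; within the scatter), not far beyond the scatter. In this assay compound 4 is estimated at 500 nM, within a range from 150 nM to 1600 nM.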

Compound 4, half-maximal effective concentration: 880 nM
Compound 4: the middle estimate sits 1.8-fold (0.25 log units) below what was measured; measured number inside the range.
By their numbers in this assay, from the lowest: compound 3; then compounds 4 and 2 (each within the scatter of the next); then compound 1.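

In this assay, going by these compounds alone, putting 4-(trifluoromethyl)phenyl in place of naphthalen-1-yl on an aromatic carbon of the five-membered aromatic ring gives a 1.1-fold lower number from compound 2 to compound 4 (0.03 log units; within the scatter), the first single-change step. Within the data shown here, at this place, then, one six-membered aromatic ring carrying trifluoromethyl and two fused aromatic rings, each group holding 10 heavy atoms, are not told apart by this read-out, and the earlier compounds could not show this because no pair among them differed in one place only. No measurement at hand accounts for this outcome.

Still open, on these data alone, is how this place responds to a group that is not an aromatic carbon ring, such as a piperidine amine or a carboxylic acid. Also open, as far as these compounds go, is whether the same swap gives a similar step on the core of compound 3.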